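The source may report more compounds than this note shows. Statements on the series, on what has been measured and on what is new or still open speak of the compounds shown alone.

Among the compounds with values here, in a functional assay on MIA PaCa-2 cells (Homo sapiens) for inhibition, read by MTT assay, with a stated time of 48 h, tested at 10 uM (a higher number here means more inhibition of growth at the concentration tested, a lower number less inhibition of growth), three compounds have numbers so far. Compound 1 `CCN(CC)Cc1c(O)c([C@H]2CCN(C)C[C@H]2O)c2oc(C)cc(=O)c2c1O` gives 27%, compound 2 `CN1CC[C@H](c2c(O)cc(O)c3c(=O)cc(/C=C/c4ccccc4)oc23)[C@H](O)C1` gives 87% and compound 3 `CN1CC[C@H](c2c(O)cc(O)c3c(=O)cc(/C=C/c4ccc(Cl)cc4)oc23)[C@H](O)C1` gives 88%. Compound 3 therefore sits level with compound 2 within the scatter, and compound 1 lies far lower, beyond the scatter.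

Compound 4 `CN1CC[C@H](c2c(O)cc(O)c3c(=O)cc(/C=C/c4cccc(Cl)c4)oc23)[C@H](O)C1` has the same atoms as compound 3, joined differently: 3-chlorophenyl in place of 4-chlorophenyl on a double-bonded chain carbon bound to a double-bonded chain carbon. Read one bond further out, the same difference is 2-(4-chlorophenyl)ethenyl to 2-(3-chlorophenyl)ethenyl. Compound 1 differs from compound 3 in more than one place and says little about this change.

Within the data shown here, the one measured step that bears on it is chloro in place of hydrogen on an aromatic carbon, a number 1 percentage points higher from compound 2 to compound 3 (within the scatter). Among the measured compounds shown here, no measured compound yet carries the 3-chlorophenyl group, so the effect of this exact change remains untested. Still, adding the chlorine to compound 2 left the value within the scatter, so relocating it is not expected to produce a step beyond the scatter in this assay. The estimated change is a number 2 percentage points lower from compound 3 to compound 4 (within the scatter). Compound 4 is therefore expected at about 86%, with an estimated range from 75% to 95%.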

Compound 4, percent growth inhibition at one concentration: 52%
The estimate for compound 4 lay 34 percentage points above the measured number; the whole stated range lies above it.
By their numbers in this assay, from the lowest: compound 1; then compound 4; then compounds 2 and 3 (each within the scatter of the next).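

In this assay, the place of the chlorine on the phenyl ring proves to matter, even though the exchanged groups have the same atoms and the same counts: going from 4-chlorophenyl to 3-chlorophenyl gives a number 36 percentage points lower from compound 3 to compound 4 (beyond the scatter). The earlier compounds shown here suggested that chloro in place of hydrogen made little difference, but that holds only for the 4-chlorophenyl group, which gave a number 1 percentage points higher from compound 2 to compound 3 (within the scatter), whereas the 3-chlorophenyl group gives a number 35 percentage points lower from compound 2 to compound 4 (beyond the scatter). The same replacement on the same core can therefore leave the number level or lower it well beyond the scatter, depending on which ring carbon carries the chlorine, and nothing at hand accounts for this difference between the two isomers.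

From the compounds shown here alone, it remains open whether the loss belongs to chlorine specifically or would follow any group at that ring carbon, a question that 3-fluorophenyl, 3-methoxyphenyl or 3-aminophenyl groups on the same double-bonded chain carbon could help settle, while 2-chlorophenyl would complete the series of chlorine placements. Going by these compounds, it is also open whether the gap between compound 3 and compound 4 would persist across a range of concentrations or in other cell lines.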